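The source may report more compounds than this note shows. Statements on the series, on what has been measured and on what is new or still open speak of the compounds shown alone.

In a toxicity assay on U-251 cells (Homo sapiens) for inhibition, read by MTT assay, with a stated time of 72 h (on this read-out lower numbers stand for stronger inhibition and higher numbers for weaker inhibition), compound 1 `c1ccc(-c2nc(CNc3nccc(N4CCCCC4)n3)cs2)cc1` gives 12300 nM. This is the lower of the two true numbers available, and the gap to compound 2 `CC(C)CNc1ccnc(NCc2csc(-c3ccc(C(F)(F)F)cc3)n2)n1`, at 29800 nM, lies beyond the usual scatter. Compound 3 `CC(C)CNc1cccc(NCc2csc(-c3ccccc3)n2)c1` gives no true number, only the assay limit of > 100000 nM.

The next compound simplifies compound 1. Compound 4 `c1ccc(-c2nc(CNc3ncccn3)cs2)cc1` has hydrogen in place of piperidin-1-yl on an aromatic carbon, a change counted as hydrogen in place of piperidin-1-yl on an aromatic carbon. Among the measured compounds shown here, no measured pair shows this change alone, so any forecast is uncertain. Compound 1 at 12300 nM and compound 2 at 29800 nM both keep a group on that carbon, whereas compound 4 has none. This offers a weak reason to expect a higher number, meaning weaker inhibition. Compound 3 cautions against a simple rule, as it also carries a side group on its ring yet reached only a limit.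

A moderate step toward weaker inhibition is therefore expected in this assay, estimated as a 3.3-fold higher number from compound 1 to compound 4 (0.51 log units; beyond the scatter). For compound 4 the expected value is 40000 nM. The estimated range for compound 4 runs from 14000 nM to 100000 nM, and a result reported only as a limit would not be surprising.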

Compound 4, half-maximal inhibitory concentration: > 100000 nM
Compound 4 gave a limit, no number; the forecaster's own chance of this, stated with the estimate: 30%; middle value at least 2.5-fold (0.39 log units) from the limit.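

Among the compounds shown here, until now no pair of measured compounds differed only at this position, so the role of the piperidin-1-yl group could only be guessed at. Replacing it with hydrogen, next to the ring nitrogen, gives an at least 8.1-fold higher number from compound 1 to compound 4 (0.91 log units; beyond the scatter), which shows that in this assay this group cannot be removed without a clear move toward weaker inhibition. Compound 4 gives a limit and not a true number, so the real size of the step remains unknown, and its result offers no measured activity to compare further: the limit of > 100000 nM in this assay, at which 2 of the 4 values shown sit.

From the compounds shown here alone, what remains open is whether the piperidine ring itself matters or whether almost any group on this carbon would serve, which a single methyl, a dimethylamino group or a morpholine ring in the same place could help separate. Compound 2 carries a different group on this carbon but also differs elsewhere, so it cannot settle the question, and the single pair shown cannot say whether the same step would appear on another version of the core.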